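Swapping cyclohexyl for benzyl on a matched pair of cores

This account rests on a few compounds, and the source may have more. Where it says the series, first, only, none or still open, it means among the compounds named here.

Of the compounds shown here, three have been measured in a functional assay on SF-295 cells (Homo sapiens) for inhibition, read by sulforhodamine B assay, with a stated time of 48 h, tested at 10 uM (on this read-out higher numbers stand for more inhibition at the one concentration tested (going by the name of the read-out) and lower numbers for less inhibition), and a fourth awaits its number. Compound 1 `O=Cc1ccc(-c2cn3ccnc3c(-c3ccc4ncn(C5CCCCC5)c4c3)n2)cc1` and compound 2 `O=Cc1ccc(-c2cn3ccnc3c(-c3ccc4ncn(Cc5ccccc5)c4c3)n2)cc1` share one core and differ only at a single spot; compound 3 `c1cn2cc(-c3ccc4c(c3)ncn4C3CCCCC3)nc(-c3ccc4ncn(C5CCCCC5)c4c3)c2n1` carries a second core. The difference between the two cores is not broken down here.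

In this assay compound 1 gives 23.1%, and compound 2 gives 23.1%. The change between them is benzyl in place of cyclohexyl on an aromatic nitrogen, and the step it made is no change at the digits printed from compound 1 to compound 2 (within the scatter). In this assay compound 3 gives 50.6%, the highest of the three numbers, beyond the scatter from the other two.

Compound 4 `c1ccc(Cn2cnc3ccc(-c4nc(-c5ccc6c(c5)ncn6C5CCCCC5)cn5ccnc45)cc32)cc1` is the unmeasured one. The change from compound 3 to compound 4 is benzyl in place of cyclohexyl on an aromatic nitrogen, the same change that turns compound 1 into compound 2, made at the same kind of place on the other core. Because that earlier step was no change at the digits printed from compound 1 to compound 2 (within the scatter), the expectation is that the step of a number 0.6 percentage points lower from compound 3 to compound 4 (within the scatter) will be small as well, with compound 4 staying close to compound 3. This rests on a single prior pair, so the estimate is held loosely. Compound 4 is expected to give about 50% in this assay, most likely between 35% and 63%.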

Compound 4, a percentage reported as inhibition, at one concentration (the size of the read-out at that concentration, not a potency): -81.4%
For compound 4 the middle estimate is 131.4 percentage points above the measured one; the measured number lies below the stated range.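

In this assay, swapping cyclohexyl for benzyl on an aromatic nitrogen did not behave the same way on the two cores, and the gap between the two results is larger than repeat measurements would explain: the same change on two cores in this assay, no change at the digits printed (within the scatter) from compound 1 to compound 2 and a number 132 percentage points lower (beyond the scatter) from compound 3 to compound 4, 132 percentage points apart, beyond the scatter of two such steps. On the second core the swap gave a number 132 percentage points lower from compound 3 to compound 4 (beyond the scatter), so a change that left the first core's reading flat cannot be assumed to be harmless elsewhere in this series, and the result for one core is a poor guide to the other. This does not show why the two cores part ways, nor does it give a general rule, since it rests on just one matched pair per core, each compound read at a single concentration in one cell line.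

The compounds shown leave open how other groups on this nitrogen would fare on each core, for example a small methyl, a longer carbon chain, or a chain ending in an amine or a carboxylic acid. They also leave open whether the sharp difference between the two cores would hold at other concentrations or in other cell lines.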